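Lengthening one chain on a xanthine-like scaffold

A few compounds are considered here, and "the series" means these few. Any claim that something is new, unique, unknown or untested is made for them only; others in the source may bear on it.

Three compounds share a core and differ only in the small chains attached to it. Compound 1 `CCCCn1c(=O)[nH]c(=O)c2[nH]cnc21` carries a butyl chain; in an assay on membranes from brain for displacement of a labelled ligand from adenosine receptor A1 (Cavia porcellus) (a higher number here means a weaker inhibitor, a lower number a stronger inhibitor), compound 1 gives 21400 nM. Compound 2 `CCCn1c(=O)n(CC)c(=O)c2c1ncn2C` carries propyl, ethyl and methyl chains, and in this assay compound 2 gives 11800 nM. Compound 3 `CCCn1c(=O)[nH]c(=O)c2c1ncn2CC` carries a propyl and an ethyl chain, and in this assay compound 3 gives 40400 nM, the highest of the three numbers: close to the value of compound 1, within the scatter, and beyond the scatter away from compound 2.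

Compound 4 `CCCn1cnc2c1c(=O)[nH]c(=O)n2CCC` is still to be measured in this assay. It differs from compound 3 by methyl in place of hydrogen on a saturated chain carbon, two bonds along the chain from an aromatic nitrogen. For the measured compounds named here, no measured pair shows this exact change, so the direction of the step is open; a step of no more than the scatter, in either direction, is expected. Compound 4 is therefore estimated at 30000 nM, within 10000 nM to 90000 nM, an expected step of a 1.3-fold lower number from compound 3 to compound 4 (0.13 log units; within the scatter) from compound 3.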

Compound 4, inhibition constant: 18200 nM
Compound 4: middle estimate off by 1.6-fold (0.22 log units), on the high side, and the stated range covers the measured number.
By their numbers in this assay, from the lowest: compounds 2, 4, 1 and 3 (each within the scatter of the next, the first and the last beyond it).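

Lengthening the chain on the aromatic nitrogen from ethyl to propyl adds a single methyl, with no ring, hydrogen-bond donor or hydrogen-bond acceptor, and gives a 2.2-fold lower number from compound 3 to compound 4 (0.35 log units; beyond the scatter) in this assay. For the compounds shown here, this is the first direct comparison in the set between two compounds that differ in one place, and it shows that the number at this position responds to a single added carbon, although the change is modest. No measurement available here accounts for this step.

As far as these compounds go, a single step cannot show a trend, so it remains open whether a butyl chain at this position would lower the number further or reverse the change. Also open, from the compounds shown here alone, is how an amine or a carboxylic acid at the end of the propyl chain would shift the number in this assay compared with compound 4.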